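This account rests on a few compounds, and the source may have more. Where it says the series, first, only, none or still open, it means among the compounds named here.

Measured in a functional assay on HeLa cells (Homo sapiens) for antiproliferative activity, read by spectrophotometry, with a stated time of 2 days; on this read-out lower numbers stand for stronger inhibition of growth and higher numbers for weaker inhibition of growth:
- compound 1 `CC(=O)N1CCN(c2ccc(Nc3ncc(C(F)(F)F)c(N4Cc5cccc(N(C)S(C)(=O)=O)c5C4)n3)cc2)CC1` gives 730 nM
- compound 2 `Cc1ccc(Nc2ncc(C(F)(F)F)c(N3Cc4cccc(N(C)S(C)(=O)=O)c4C3)n2)cc1C` gives > 30000 nM as a limit of the assay
- compound 3 `COc1cc(N2CCN(C(C)=O)CC2)ccc1Nc1ncc(C(F)(F)F)c(N2Cc3cccc(N(C)S(C)(=O)=O)c3C2)n1` gives 1300 nM

Compound 2 stands at the limit of > 30000 nM in this assay, at which 1 of the 3 values shown sits, and so has no exact number. Compound 4 `Cc1ccc(Nc2ncc(C(F)(F)F)c(N3Cc4cccc(N(C)S(C)(=O)=O)c4C3)n2)c(Cl)c1` has not been measured yet. It carries 2-chloro-4-methylphenyl in place of 3,4-dimethylphenyl on a nitrogen on an aromatic ring. The heavy-atom count stays the same, and the counted donors and acceptors of the two groups do not differ.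

Going by the values given here, only one measured step offers any guide, and it is a different change: methoxy in place of hydrogen on an aromatic carbon. That swap gave a 1.8-fold higher number from compound 1 to compound 3 (0.25 log units; within the scatter) and so stayed small. It is thin evidence, since it comes from a single pair and not from compound 2 itself. On that basis, a swap on an aromatic ring is expected to produce no step beyond the scatter in this assay, and no clear direction can be predicted. The estimated change is a number no higher from compound 2 to compound 4 (the limit leaves the size open) and should be read against a starting point that is only a limit. For compound 4 the expected value is 30000 nM on this estimate, with an expected range from 9000 nM to 60000 nM overall.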

Compound 4, concentration for 50% growth inhibition: 10900 nM
Compound 4: the middle estimate sits 2.8-fold (0.44 log units) above what was measured, within the range that was stated.
By their numbers in this assay, from the lowest: compounds 1 and 3 (each within the scatter of the next); then compound 4. At a limit, above all of these: compound 2.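

In this assay, 2-chloro-4-methylphenyl in place of 3,4-dimethylphenyl on a nitrogen on an aromatic ring gives an at least 2.7-fold lower number from compound 2 to compound 4 (0.43 log units; beyond the scatter). Going by these compounds alone, this shows that the number in this assay responds to what the phenyl ring at this nitrogen carries, and that a chlorine-bearing ring of the same heavy-atom count brings the compound back to a measurable value; the only earlier step, a methoxy swap on a different compound, stayed within the scatter and could not show this. The size of the new step is only a minimum, and no cause for it can be drawn from these data, since compound 2 has no exact number: the limit of > 30000 nM in this assay, at which 1 of the 4 values shown sits.

The change brings in a chlorine and also alters the methyl pattern, so the compounds shown cannot say which of these two differences accounts for the step. Also open, on these data alone, is whether a bromine or a fluorine in place of the chlorine, or a morpholine in place of the methyl, would move the number further in either direction.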